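The source may hold more compounds than are shown below. What is called first, only, known or untested is meant among the compounds shown, and "the series" means these compounds.

Compound 1 `Oc1cccc(-c2cc(-c3cccs3)cc(-c3ccccc3O)n2)c1`: 83.2%
Compound 2 `Oc1cccc(-c2cc(-c3ccsc3)cc(-c3ccccc3O)n2)c1`: 10.2%
Compound 3 `Oc1cccc(-c2cc(-c3ccoc3)cc(-c3ccccc3O)n2)c1`: 29.5%

In an assay on isolated protein for inhibition of DNA topoisomerase 1 (Homo sapiens), with a stated time of 30 min, tested at 100 uM (a higher number here means a stronger effect of the compound at the concentration tested, a lower number a weaker effect), compound 3 stands second highest of these three numbers; its nearest neighbour is compound 2, with a number 19.3 percentage points higher from compound 2 to compound 3 (beyond the scatter), and its furthest is compound 1, with a number 53.7 percentage points lower from compound 1 to compound 3 (beyond the scatter). Compound 4 `Oc1cccc(-c2cc(-c3cccnc3)cc(-c3ccccc3O)n2)c1` is the next compound to consider, and it differs from compound 3 as follows: pyridin-3-yl in place of furan-3-yl on an aromatic carbon. The steps measured so far all swap the five-membered ring at this place: a number 73 percentage points lower from compound 1 to compound 2 (beyond the scatter) and a number 53.7 percentage points lower from compound 1 to compound 3 (beyond the scatter) were large, a number 19.3 percentage points higher from compound 2 to compound 3 (beyond the scatter) was modest. Among the compounds with values here, each such swap moved the number beyond the scatter, so a change here is expected for compound 4 too, but no measured step involves pyridin-3-yl, so its direction is uncertain. Compound 4 is therefore expected to give 30%, ranging from 5% to 60%, a step of a number 0.5 percentage points higher from compound 3 to compound 4 (within the scatter).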

Compound 4, a percentage reported as inhibition, at one concentration (the size of the read-out at that concentration, not a potency): 1.9%
Compound 4: the middle estimate sits 28.1 percentage points above what was measured; the measured number lies below the stated range.
By their numbers in this assay, from the lowest: compounds 4 and 2 (each within the scatter of the next); then compound 3; then compound 1.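

In this assay the first six-membered ring at this place gives a number 27.6 percentage points lower from compound 3 to compound 4 (beyond the scatter) and also a number 81.3 percentage points lower from compound 1 to compound 4 (beyond the scatter) while the swap from thiophen-3-yl gives a number 8.3 percentage points lower from compound 2 to compound 4 (within the scatter) and so separates nothing. Among these compounds, pyridin-3-yl thus stands clear of thiophen-2-yl and furan-3-yl but not of thiophen-3-yl. Nothing given here explains these differences.

Still open, on these data alone, is whether furan-2-yl, an unsubstituted phenyl ring or pyridin-2-yl at this place would match compound 1. As far as these compounds go, an amine or a short alkyl chain here is equally open.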